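The source may hold more compounds than are shown below. What is called first, only, known or untested is meant among the compounds shown, and "the series" means these compounds.

Measured compounds:
- compound 1, `C=C[C@@](C)(/C=C/c1ccc(OC)cc1)CCC=C(C)C`: > 36600 nM
- compound 2, `C=C[C@@](C)(/C=C/c1ccc(Nc2cccc(C(F)(F)F)c2)cc1)CCC=C(C)C`: > 36600 nM

In an ADME assay on BJ cells (Homo sapiens) for cytotoxicity, with a stated time of 72 h (a lower number here means that less compound is needed, a higher number that more compound is needed for the effect), compound 1 gives > 36600 nM, which is a limit of the assay rather than a number. Compound 2 gives > 36600 nM in this assay, again a limit. For the measured compounds named here, compound 1 thus stands at the limit of > 36600 nM in this assay, at which 2 of the 2 values shown sit, with no number of its own, and no step between measured compounds that differ in one place is available. Compound 3, `C=C[C@@](C)(/C=C/c1ccc(-c2ccc(Cl)c(Cl)c2)cc1)CCC=C(C)C`, has not yet been measured. It differs from compound 1 by 3,4-dichlorophenyl in place of methoxy on an aromatic carbon. With only two limits to draw on, the change has no measured basis, so in this assay a step of an at least 1.2-fold lower number from compound 1 to compound 3 (0.08 log units; that floor lies within the scatter) is expected, that is, none beyond the scatter. Compound 3 is therefore estimated to give about 30000 nM in this assay, between 8000 nM and 80000 nM, most likely again reported only as a limit.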

Compound 3, half-maximal effective concentration: > 36600 nM
Compound 3: no number, only a limit; the forecaster's own chance of this, stated with the estimate: 60%; at least 1.2-fold (0.08 log units) between middle value and limit.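

For the compounds shown here, compound 1 and compound 3 both stand only at a limit in this assay, not at a number, so no step between them can be read. As far as these compounds go, what stays open is how much of each compound the effect takes, and whether 3,4-dichlorophenyl in place of methoxy changes that amount.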